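Diethylamino for (propylcarbonyl)oxy on the side chain

The source may hold more compounds than are shown below. What is called first, only, known or untested is meant among the compounds shown, and "the series" means these compounds.

In a functional assay on L1210 cells (Mus musculus) for inhibition (a lower number here means a stronger inhibitor, a higher number a weaker inhibitor), compound 1 (`COC1=CC(=O)c2ncnc(NCCCN(C)C)c2C1=O`) gives 0.501 ug/mL and compound 2 (`CCCC(=O)OCCNc1ncnc2c1C(=O)C(OC)=CC2=O`) gives 0.85 ug/mL with the two values within the scatter of each other, so the numbers shown do not separate them. Compound 3 (`CCN(CC)CCNc1ncnc2c1C(=O)C(OC)=CC2=O`) has no number yet. The change from compound 2 is diethylamino in place of (propylcarbonyl)oxy on a saturated chain carbon, two bonds along the chain from a nitrogen on an aromatic ring and in words it is diethylamino in place of (propylcarbonyl)oxy on a saturated chain carbon, two bonds along the chain from a nitrogen on an aromatic ring.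

Within the data shown here, one measured step bears on this: a 1.7-fold higher number from compound 1 to compound 2 (0.23 log units; within the scatter) with (propylcarbonyl)oxy in place of (dimethylamino)methyl on a saturated chain carbon. Among the measured compounds shown here, no diethylamino compound has a number so far, and a single step is thin evidence. With that one step as the guide, the expected move a 1.4-fold lower number from compound 2 to compound 3 (0.15 log units; within the scatter) is none beyond the scatter. The estimate for compound 3 is 0.6 ug/mL and it is expected to fall between 0.2 ug/mL and 1.8 ug/mL.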

Compound 3, half-maximal inhibitory concentration: 0.281 ug/mL
Compound 3: the middle estimate sits 2.1-fold (0.33 log units) above what was measured; low and high end bracket the measured number.
By their numbers in this assay, from the lowest: compounds 3, 1 and 2 (each within the scatter of the next, the first and the last beyond it).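

Among these compounds, at this place, on a saturated chain carbon, two bonds along the chain from a nitrogen on an aromatic ring, diethylamino in place of (propylcarbonyl)oxy gives the first step in this assay that clears the scatter: a 3.0-fold lower number from compound 2 to compound 3 (0.48 log units; beyond the scatter), a modest move. Diethylamino in place of (dimethylamino)methyl gives a 1.8-fold lower number from compound 1 to compound 3 (0.25 log units; within the scatter), so the two amine-bearing side chains are not separated, and compound 2 stands apart from compound 3 but not from compound 1. Nothing on hand explains why the (propylcarbonyl)oxy and diethylamino groups part here while the other two pairs do not.

On these data alone, with three compounds and one modest step, it remains open whether an amine at this place is what matters or whether the (propylcarbonyl)oxy group is simply a poorer fit among many possible groups. A hydroxyl, a carboxylic acid or a morpholine at the same carbon, together with a longer chain carrying diethylamino, would show whether the step belongs to the amine nitrogen or to the particular groups compared so far.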